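This account rests on a few compounds, and the source may have more. Where it says the series, first, only, none or still open, it means among the compounds named here.

The measured compounds:
Compound 1 `CNc1nc(Nc2ccc(C(C)=O)cc2)c2nc[nH]c2n1` gives, in an ADME assay on Vero cells (Chlorocebus sabaeus) for cytotoxicity (a lower number here means that less compound is tolerated, a higher number that more compound is tolerated), a value that is only a limit of the assay, > 177000 nM.
Compound 2 `CC(=O)c1ccc(Nc2nc(NCCO)nc3[nH]cnc23)cc1` gives in this assay 160000 nM.
Compound 3 `OCCNc1nc(Nc2cccc(O)c2)c2nc[nH]c2n1` gives in this assay a value that is again only a limit, > 175000 nM.

Compound 1 and compound 2 share a core and differ in one place: hydrogen in place of hydroxymethyl on a saturated chain carbon bound to a nitrogen on an aromatic ring. The step in this assay is an at least 1.1-fold higher number from compound 2 to compound 1 (0.04 log units; that floor lies within the scatter), and because one end of it is the limit of > 177000 nM in this assay, at which 1 of the 3 values shown sits, its true size cannot be told. How the core of compound 3 differs from that of compound 2 is not broken down here.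

Compound 4 `CNc1nc(Nc2cccc(O)c2)c2nc[nH]c2n1` is not yet measured. It is made from compound 3 by the same change: hydrogen in place of hydroxymethyl on a saturated chain carbon bound to a nitrogen on an aromatic ring. Among the compounds with values here, in the one measured case this change left the value at the assay limit, so for compound 4 the step in this assay is expected to be a step that the limit leaves unreadable from compound 3 to compound 4, most likely ending again at a limit. The expected value for compound 4 is therefore 180000 nM, within a range from 110000 nM to 400000 nM.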

Compound 4, half-maximal cytotoxic concentration: 168000 nM
Compound 4: middle estimate off by 1.1-fold (0.03 log units), on the high side; measured number inside the range.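

On these data alone, changing 2-hydroxyethyl to methyl in this assay gives an at least 1.0-fold lower number from compound 3 to compound 4 (0.01 log units; that floor lies within the scatter), so this second core, like the first, offers no sign of a step beyond the scatter, though the true size of the step stays unknown. The result is therefore consistent with the change carrying over from one core to the other, but it does not show that the change acts alike on both, as the two steps cannot be compared exactly: the same change on two cores in this assay, an at least 1.1-fold higher number (0.04 log units; that floor lies within the scatter) from compound 2 to compound 1 and an at least 1.0-fold lower number (0.01 log units; that floor lies within the scatter) from compound 3 to compound 4; the limit leaves it open whether they differ. The value of compound 3 is only a limit, and this is what keeps the new step from being read in full: the limit of > 175000 nM in this assay, at which 1 of the 4 values shown sits.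

The compounds shown carry only 2-hydroxyethyl or methyl in this place, on just two cores, so it stays open whether the change would hold on a further core. As far as these compounds go, it also stays open how a longer chain, an amine or a carboxylic acid in the same place would read in this assay.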